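Acetyl(methyl)amino in place of 5-hydroxy-2-oxopiperidin-1-yl

This account rests on a few compounds, and the source may have more. Where it says the series, first, only, none or still open, it means among the compounds named here.

Measured so far in a physicochemical assay for lipophilicity, measured as octanol-water partition, at pH 7.4; on this read-out lower numbers stand for lower lipophilicity and higher numbers for higher lipophilicity:
- compound 1 `CCc1cnc(N2CCC(C(C)COC(=O)N3CCc4cc(S(C)(=O)=O)cc(F)c43)CC2)nc1` gives 3.6
- compound 2 `CC(C)c1noc(N2CCC(Oc3cc(N4CCc5cc(N6CCCNS6(=O)=O)ccc54)ncn3)CC2)n1` gives 3.2
- compound 3 `CC(C)c1noc(N2CCC(Oc3cc(N4CCc5cc(N6CC(O)CCC6=O)ccc54)ncn3)CC2)n1` gives 2.6

Compound 3 holds the lowest of the three numbers. Compound 2 lies nearest to it and compound 1 furthest, both gaps beyond the scatter. Compound 4 `CC(=O)N(C)c1ccc2c(c1)CCN2c1cc(OC2CCN(c3nc(C(C)C)no3)CC2)ncn1` is not yet measured. It carries acetyl(methyl)amino in place of the 5-hydroxy-2-oxopiperidin-1-yl of compound 3, on an aromatic carbon (acetyl(methyl)amino in place of 5-hydroxy-2-oxopiperidin-1-yl on an aromatic carbon).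

One measured step changes the same place (a number 0.60 log units lower from compound 2 to compound 3 (beyond the scatter)). It was modest but beyond the scatter, so a group swap here can move the number. Among the measured compounds shown here, no measured step involves an open-chain group, which leaves the direction weakly supported. With compound 3 at the low end (2.6), a modest upward step in this assay is expected. The expected change is an estimated rise (a number 0.40 log units higher from compound 3 to compound 4 (beyond the scatter)). The estimate for compound 4 is 3 within an expected range of 2.6 to 3.4.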

Compound 4, distribution coefficient: 3.7
Compound 4: middle estimate off by 0.70 log units, on the low side; measured number outside the range, above it.
By their numbers in this assay, from the lowest: compound 3; then compound 2; then compounds 1 and 4 (each within the scatter of the next).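

In this assay this position spans a wider range than the earlier pair showed: acetyl(methyl)amino gives a number 1.10 log units higher from compound 3 to compound 4 (beyond the scatter) and, against the six-membered ring of compound 2, a number 0.50 log units higher from compound 2 to compound 4 (beyond the scatter) with the same group. Among the three groups seen on this aromatic carbon, the open-chain acetyl(methyl)amino of compound 4 therefore gives the highest number, and the 5-hydroxy-2-oxopiperidin-1-yl of compound 3 the lowest. No supporting measurement accounts for the size of this rise.

As far as these compounds go, the step from compound 3 to compound 4 removes the ring, the hydrogen-bond donor and heavy atoms together, so the share of each stays open. Also open, from the compounds shown here alone, is where a tertiary amine, a carboxylic acid or a longer acyl chain on the same nitrogen would fall at this position.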